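Flipping the Double Bond from Z to E

This account rests on a few compounds, and the source may have more. Where it says the series, first, only, none or still open, it means among the compounds named here.

Measured compounds:
Compound 1 `O=Cc1cccc(OCc2cn(Cc3ccccc3)nn2)c1`: > 50000 nM in a functional assay on A549 cells (Homo sapiens) for inhibition, read by MTT assay, with a stated time of 48 h (on this read-out higher numbers stand for weaker inhibition and lower numbers for stronger inhibition), a limit of the assay rather than a number.
Compound 2 `COc1cc(Cn2cc(COc3cccc(/C=C4\C(=O)Nc5ccccc54)c3)nn2)cc(OC)c1`: 43300 nM in this assay.

Going by the values given here, compound 2 holds the only actual number in this assay; the other value is a limit, namely (the limit of > 50000 nM in this assay, at which 1 of the 2 values shown sits). Compound 3 `COc1cc(Cn2cc(COc3cccc(/C=C4/C(=O)Nc5ccccc54)c3)nn2)cc(OC)c1` keeps every atom and bond of compound 2 and changes only the drawn geometry: the two compounds have the same atoms and bonds and differ only in configuration as drawn: 1 of 1 stereo elements differ; a double bond is drawn Z in compound 2 and E in compound 3. Among the compounds with values here, no pair of measured compounds shows what such a Z-to-E switch does here, so there is no measured step to lean on. The expectation is a step in this assay from compound 2 to compound 3 of a 1.2-fold lower number from compound 2 to compound 3 (0.09 log units; within the scatter), which is expected to stay within the usual scatter, with the direction left open. For compound 3 the estimated value in this assay is 35000 nM, expected to fall between 8000 nM and 150000 nM.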

Compound 3, half-maximal inhibitory concentration: 26700 nM
Compound 3: the middle estimate sits 1.3-fold (0.12 log units) above what was measured; the measured number falls inside the stated range.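

Here, for the first time, a single change can be read on its own, a double bond going from Z to E: in this assay the switch gives a 1.6-fold lower number from compound 2 to compound 3 (0.21 log units; within the scatter). At this position, then, the drawn geometry of the double bond makes no difference that can be told apart from ordinary repeat-to-repeat variation in this assay. The comparison is a clean one, with nothing else to account for: the fact that compounds 2 and 3 differ only in the configuration as drawn

Compound 1 gives > 50000 nM, which is a limit, and it differs from compound 2 in more than one place, so what separates them stays unresolved. The compounds shown also leave open whether an amine or a carboxylic acid on the shared core would shift the number beyond the scatter, and whether the double bond geometry would matter then.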